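Triazole-linked oximes against prostate cancer cells: a substituent swap

The source may hold more compounds than are shown below. What is called first, only, known or untested is meant among the compounds shown, and "the series" means these compounds.

Measured so far:
compound 1, `C#CCO/N=C1/C[C@@H](c2ccc(OC)cc2)Oc2cc(OC)c(CC=C(C)C)cc21`, 41%
compound 2, `COc1ccc([C@@H]2C/C(=N/OCc3cn(-c4ccc(C(=O)c5ccccc5)cc4)nn3)c3cc(CC=C(C)C)c(OC)cc3O2)cc1`, 40%
compound 3, `COc1ccc([C@@H]2C/C(=N/OCc3cn(-c4cccc(CO)c4)nn3)c3cc(CC=C(C)C)c(OC)cc3O2)cc1`, 34%

Of the compounds shown here, three sharing one core have been tested in a functional assay on PC-3 cells (Homo sapiens) for inhibition, read by sulforhodamine B assay, with a stated time of 48 h, tested at 50 uM; on this read-out lower numbers stand for less inhibition of growth and higher numbers for more inhibition of growth at the one concentration tested. Compound 1 gives 41%, compound 2 gives 40% and compound 3 gives 34%. On these numbers compound 3 stands lowest of the three, but its gap to compound 2 and its gap to compound 1 both fall within the scatter of the method, so the three figures cannot be told apart with confidence.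

Compound 4, `COc1ccc([C@@H]2C/C(=N/OCc3cn(-c4ccc(O)cc4)nn3)c3cc(CC=C(C)C)c(OC)cc3O2)cc1`, has not yet been measured in this assay. It differs from compound 3 in one place: 4-hydroxyphenyl in place of 3-(hydroxymethyl)phenyl on an aromatic nitrogen. Compound 2 and compound 3 already carry two different aryl groups on that same aromatic nitrogen and give numbers within the scatter of each other, so a third aryl group there is not expected to move the read-out by much. The step from compound 3 to compound 4 is therefore expected to be small, a number 2 percentage points higher from compound 3 to compound 4 (within the scatter), with no direction beyond the scatter. Compound 4 is estimated at 36%, with a range from 22% to 50%.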

Compound 4, percent growth inhibition at one concentration: 64%
Estimate against measurement, compound 4: 28 percentage points below, and the stated range ends below it.
By their numbers in this assay, from the lowest: compounds 3, 2 and 1 (each within the scatter of the next); then compound 4.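

In this assay, compounds 2 and 3 had given no sign that the aryl group on this aromatic nitrogen could matter much, yet 4-hydroxyphenyl in place of 3-(hydroxymethyl)phenyl gives a number 30 percentage points higher from compound 3 to compound 4 (beyond the scatter), so this position can move the read-out well past the scatter. Compound 4 also stands apart from the other two compounds: hydroxy in place of benzoyl on an aromatic carbon gives a number 24 percentage points higher from compound 2 to compound 4 (beyond the scatter), and 1-(4-hydroxyphenyl)-1H-1,2,3-triazol-4-yl in place of ethynyl gives a number 23 percentage points higher from compound 1 to compound 4 (beyond the scatter), which shows that the gain comes with this particular aryl group and not with any aryl group on the five-membered ring. No measurement at hand bears on the reason for this rise.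

The step from compound 3 to compound 4 changes both the group on the phenyl ring and its place there, so the compounds shown do not tell which of the two carries the gain. From the compounds shown here alone, it also remains open whether an amine or a methoxy group in place of the hydroxy of compound 4 would keep the number this high, and whether that number holds at other concentrations.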